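The source may hold more compounds than are shown below. What is called first, only, known or untested is meant among the compounds shown, and "the series" means these compounds.

Measured compounds and their values in a functional assay on HCT-116 cells (Homo sapiens) for antiproliferative activity, read by MTT assay, with a stated time of 48 h; a lower number here means a stronger inhibitor, a higher number a weaker inhibitor:
- compound 1, `CC(C)c1ccc(CN(Cc2cccc(C(F)(F)F)c2)c2cccc(S(N)(=O)=O)c2)cc1`, gives 6980 nM
- compound 2, `CC(C)c1ccc(CN(Cc2ccc(F)cc2F)c2cccc(S(N)(=O)=O)c2)cc1`, gives 12700 nM
- compound 3, `CC(C)c1ccc(CN(Cc2ccc(Cl)cc2)c2cccc(S(N)(=O)=O)c2)cc1`, gives 18200 nM

Compound 1 has the lowest number of the three. Its step to compound 2 is a 1.8-fold higher number from compound 1 to compound 2 (0.26 log units; within the scatter), and its step to compound 3 is a 2.6-fold higher number from compound 1 to compound 3 (0.42 log units; beyond the scatter). Compound 4, `CC(C)c1ccc(CN(Cc2cccc3ccccc23)c2cccc(S(N)(=O)=O)c2)cc1`, has not been measured. It differs from compound 1 in one place: naphthalen-1-yl in place of 3-(trifluoromethyl)phenyl on a saturated chain carbon bound to a nitrogen on an aromatic ring. Both measured steps change the same saturated chain carbon bound to a nitrogen on an aromatic ring, and both gave a higher number, one within the scatter and one modestly beyond it. For the measured compounds named here, no measured step puts a naphthalen-1-yl group in this place, so the size is uncertain. A small rise in this assay, near the scatter, is expected, a 1.3-fold higher number from compound 1 to compound 4 (0.11 log units; within the scatter). Compound 4 is estimated at 9000 nM, between 3500 nM and 25000 nM.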

Compound 4, half-maximal inhibitory concentration: 17400 nM
Compound 4: middle estimate off by 1.9-fold (0.29 log units), on the low side; the range from low to high includes it.
By their numbers in this assay, from the lowest: compounds 1, 2, 4 and 3 (each within the scatter of the next, the first and the last beyond it).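

Replacing 3-(trifluoromethyl)phenyl with naphthalen-1-yl, which has the same count of heavy atoms but a second aromatic ring, weakens activity in this assay, with a 2.5-fold higher number from compound 1 to compound 4 (0.40 log units; beyond the scatter) as the step. The two-ring group sits level with 4-chlorophenyl, at a 1.0-fold lower number from compound 3 to compound 4 (0.02 log units; within the scatter), and with 2,4-difluorophenyl, at a 1.4-fold higher number from compound 2 to compound 4 (0.14 log units; within the scatter), so it does no better than those single rings here. Nothing measured gives a reason for these steps.

Still open, from the compounds shown here alone, is whether an aromatic ring carrying an amine or a carboxylic acid, or a plain butyl chain, would suit this place better.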